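A few compounds are considered here, and "the series" means these few. Any claim that something is new, unique, unknown or untested is made for them only; others in the source may bear on it.

Compound 1 `CCCCCCCCNC(=O)[C@@H](NC(=O)c1ccccc1)[C@@H](C)O` and compound 2 `CCCCCCCCNC(=O)[C@@H](NC(=O)c1ccco1)[C@@H](C)O` share one core, while compound 3 `CCCCCCCCCCCCCCCCCCNC(=O)[C@@H](NC(=O)c1ccccc1)[C@@H](C)O` carries a longer chain on that core. In a functional assay on SW-620 cells (Homo sapiens) for cytotoxicity, read by MTT assay, with a stated time of 48 h (on this read-out lower numbers stand for stronger inhibition and higher numbers for weaker inhibition), compound 1 gives 200000 nM, compound 2 gives 200000 nM, and compound 3 gives 200000 nM. The change from compound 1 to compound 2 is furan-2-yl in place of phenyl on a carbonyl carbon, and the step it made in this assay was no change at the digits printed from compound 1 to compound 2 (within the scatter). The core of compound 3 differs from that of compound 1 by decyl in place of hydrogen on a saturated chain carbon, eight bonds along the chain from an amide-type nitrogen, a step of no change at the digits printed from compound 1 to compound 3 (within the scatter). Compound 4 `CCCCCCCCCCCCCCCCCCNC(=O)[C@@H](NC(=O)c1ccco1)[C@@H](C)O` has not yet been measured; it differs from compound 3 by furan-2-yl in place of phenyl on a carbonyl carbon, the same change at the same place. Because the earlier step was no change at the digits printed from compound 1 to compound 2 (within the scatter), the step from compound 3 to compound 4 in this assay is expected to be no change at the digits printed from compound 3 to compound 4 (within the scatter). Compound 4 is therefore estimated at 200000 nM.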

Compound 4, half-maximal inhibitory concentration: > 200000 nM
Compound 4 ended at the assay's limit; the forecaster's own chance of this, stated with the estimate: 60%; the middle value sits exactly at the limit.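

In this assay compound 4 gives > 200000 nM, which is a limit of the assay and not a number. The steps to compound 4 therefore cannot be read in size, and furan-2-yl in place of phenyl on the core of compound 3 gives only this (a number no lower from compound 3 to compound 4 (the limit leaves the size open)), so nothing here shows whether that change acts alike on the two cores: the same change on two cores in this assay, no change at the digits printed (within the scatter) from compound 1 to compound 2 and a number no lower (the limit leaves the size open) from compound 3 to compound 4; the limit leaves it open whether they differ The longer chain on the core of compound 2 likewise gives only this (a number no lower from compound 2 to compound 4 (the limit leaves the size open)) and leaves the same question unanswered, so the result neither supports nor refutes carrying either change from one core to another: the same change on two cores in this assay, no change at the digits printed (within the scatter) from compound 1 to compound 3 and a number no lower (the limit leaves the size open) from compound 2 to compound 4; the limit leaves it open whether they differ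

The compounds shown leave open whether this series can give a clearly readable value in this assay. A ring bearing an amine or a carboxylic acid in place of the phenyl, or a shorter chain, might help answer that.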